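This account rests on a few compounds, and the source may have more. Where it says the series, first, only, none or still open, it means among the compounds named here.

Values so far in a functional assay on DU-145 cells (Homo sapiens) for cytotoxicity, read by sulforhodamine B assay, with a stated time of 3 days; a higher number here means that more compound is needed for the effect, a lower number that less compound is needed
compound 1 `CCOCc1c(C)coc1-c1ccc2c(c1OC)CCCC2(C)C` gives 17.7 uM
compound 2 `Cc1coc(-c2ccc3c(c2O)CCCC3(C)C)c1C(=O)O` gives 3 uM
compound 3 `COc1c(-c2occ(C)c2C(=O)O)ccc2c1CCCC2(C)C` gives 34.1 uM

Compound 2 holds the lowest number of the three. The gap to compound 3 is large, at an 11-fold higher number from compound 2 to compound 3 (1.06 log units; beyond the scatter), and this step is methyl in place of hydrogen on an oxygen on an aromatic ring. Compound 1 also stands well above compound 2.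

The next comparison is with compound 4 `Cc1coc(-c2ccc3c(c2O)CCCC3(C)C)c1CO`, which differs from compound 2 as follows: hydroxymethyl in place of carboxy on an aromatic carbon. In short, this is hydroxymethyl in place of carboxy on an aromatic carbon.

Going by the values given here, only one measured step touches that place, namely a 1.9-fold higher number from compound 1 to compound 3 (0.28 log units; within the scatter), with carboxy in place of ethoxymethyl. It stays within the scatter, but it was measured with methyl rather than hydrogen on the oxygen, and hydroxymethyl itself has not been measured in this series. The large step on the oxygen lies elsewhere and sets no size here, although it warns that the smaller step may not carry over to the hydrogen-bearing compounds.

The expected result is a 1.3-fold higher number from compound 2 to compound 4 (0.12 log units; within the scatter), so no step beyond the scatter is anticipated, in either direction. The estimate for compound 4 is 4 uM, with an expected range from 1.5 uM to 12 uM.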

Compound 4, concentration for half-maximal effect: 22.7 uM
For compound 4 the middle estimate is 5.7-fold (0.75 log units) below the measured one; the whole stated range lies below it.
By their numbers in this assay, from the lowest: compound 2; then compounds 1, 4 and 3 (each within the scatter of the next).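

Position notes: in this assay, the place on the five-membered aromatic ring with 1 oxygen proves sensitive when hydrogen sits on the oxygen on the aromatic ring: hydroxymethyl in place of carboxy gives a step beyond the scatter (a 7.6-fold higher number from compound 2 to compound 4 (0.88 log units; beyond the scatter)). Going by these compounds alone, the only earlier step at this place, carboxy in place of ethoxymethyl, was read with methyl on that oxygen and stayed within the scatter (a 1.9-fold higher number from compound 1 to compound 3 (0.28 log units; within the scatter)), so that small step does not carry over to this different change in the hydrogen-bearing compounds. Compound 2 now loses its low number through a single change at either of two places, since methyl in place of hydrogen on the oxygen also gives a step beyond the scatter (an 11-fold higher number from compound 2 to compound 3 (1.06 log units; beyond the scatter)). Nothing at hand gives a reason for the size of the new step.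

Still open, from the compounds shown here alone, is whether carboxy itself is needed at this place, or whether a methyl ester, a primary amide or a tetrazole would hold the number of compound 2. The shown compounds also leave open what ethoxymethyl does with hydrogen on the oxygen, and what hydroxymethyl does with methyl there.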